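The compounds below may be only part of what the source reports. "The series", "measured", "known", "first", "only" and "open" are said of these compounds alone.

Compound 1 `CCOc1ccnc(N2CCN(c3cc(N)c4cc(OC)c(OC)cc4n3)CC2)n1` and compound 2 `COc1cc2nc(N3CCN(C(=O)Nc4ccccc4)CC3)cc(N)c2cc1OC` share a core and differ only on a ring nitrogen, where compound 2 carries a phenylcarbamoyl group. In an assay on brain for displacement of a labelled ligand from Adrenergic receptor alpha-1 (Rattus norvegicus) (on this read-out higher numbers stand for weaker inhibition and lower numbers for stronger inhibition), compound 1 gives 0.42 nM, and compound 2 gives 0.34 nM; the step of a 1.2-fold lower number from compound 1 to compound 2 (0.09 log units; within the scatter) is within the scatter, so the two numbers count as alike, and compound 2 stands together with compound 1 rather than apart from it. Compound 3 `COc1cc2nc(N3CCN(C(C)=O)CC3)cc(N)c2cc1OC` takes the phenylcarbamoyl of compound 2 down to an acetyl: methyl in place of anilino on a carbonyl carbon. Among the compounds with values here, the one measured step, from a pyrimidinyl to a phenylcarbamoyl, swapped one ring-bearing group for another without a change beyond the scatter, and it does not directly show what removing the ring and leaving only a methyl does. The expected step of an 8.8-fold higher number from compound 2 to compound 3 (0.95 log units; beyond the scatter) is therefore a modest loss, and compound 3 is estimated at 3 nM, within 0.5 nM to 20 nM.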

Compound 3, inhibition constant: 1.17 nM
For compound 3 the middle estimate is 2.6-fold (0.41 log units) above the measured one, within the range that was stated.
By their numbers in this assay, from the lowest: compounds 2 and 1 (each within the scatter of the next); then compound 3.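

In this assay, within the data shown here, methyl in place of anilino on a carbonyl carbon gives a 3.4-fold higher number from compound 2 to compound 3 (0.54 log units; beyond the scatter) and is the first change at this ring nitrogen to move the number beyond the scatter, showing that the group held here can matter, though only modestly. Acetyl in place of 4-ethoxypyrimidin-2-yl gives a 2.8-fold higher number from compound 1 to compound 3 (0.44 log units; beyond the scatter), so among these three compounds the two groups carrying a ring stand together and the acetyl group, with no ring, stands apart from both. The data shown offer no measured explanation for this difference.

Anilino takes away both an aromatic ring and a hydrogen-bond donor, so these compounds do not separate the two. Going by these compounds, whether a cyclohexyl group or a longer chain such as butyl on the same carbonyl carbon would behave like anilino or like methyl remains open.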